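Ethyl for pyrimidin-2-yl: working notes on compound 3

The source may report more compounds than this note shows. Statements on the series, on what has been measured and on what is new or still open speak of the compounds shown alone.

Compound 1 `C[C@@H]1CN(c2cccc3c2C[C@H](CN(C)[C@H]2CCCc4cccnc42)NC3)C[C@H](C)N1C` gives 39.6%
Compound 2 `CN(C[C@H]1Cc2c(cccc2N2CCN(c3ncccn3)CC2)CN1)[C@H]1CCCc2cccnc21` gives 35.1%

In an ADME assay on microsomes from liver (Mus musculus) for metabolic stability, read by LC-MS, with a stated time of 10 min (on this read-out lower numbers stand for a less stable compound and higher numbers for a more stable compound), compound 2 at 35.1% lies within the usual scatter of compound 1 at 39.6% and the two cannot be told apart. Compound 3 `CCN1CCN(c2cccc3c2C[C@H](CN(C)[C@H]2CCCc4cccnc42)NC3)CC1` differs from compound 2 by ethyl in place of pyrimidin-2-yl on an amine nitrogen in a ring and the shared core stays as it is. Going by the values given here, no measured pair isolates this change, so the data give no direct size for it. Among the compounds with values here, compound 1 carries no pyrimidin-2-yl and gives 39.6% in this assay as the only indirect guide. The expected step is a number 2.9 percentage points higher from compound 2 to compound 3 (within the scatter) and it is not expected to go beyond the scatter. For compound 3 the estimated value is 38% with an expected range from 22% to 55% in this read-out.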

Compound 3, percent of the compound remaining: 18.8%
Compound 3: the middle estimate sits 19.2 percentage points above what was measured; the whole stated range lies above it.
By their numbers in this assay, from the lowest: compound 3; then compounds 2 and 1 (each within the scatter of the next).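

In this assay the group on this amine nitrogen in a ring now clearly matters: ethyl in place of pyrimidin-2-yl gives a number 16.3 percentage points lower from compound 2 to compound 3 (beyond the scatter) whereas compound 1 and compound 2, which carry quite different groups, could not be told apart. With 4-ethylpiperazin-1-yl in place of 3,4,5-trimethylpiperazin-1-yl on an aromatic carbon, the result is a number 20.8 percentage points lower from compound 1 to compound 3 (beyond the scatter) and compound 3 therefore stands lowest of the three. No measurement at hand gives a reason for either step.

On these data alone, it remains open whether the low number belongs to ethyl alone or extends to other alkyl groups on this nitrogen, such as methyl, isopropyl or a longer chain. As far as these compounds go, it is equally open whether a different aromatic ring such as pyridin-2-yl, or an acyl group such as acetyl, would stay level with compound 2 in this read-out.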